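The source may report more compounds than this note shows. Statements on the series, on what has been measured and on what is new or still open speak of the compounds shown alone.

Among the compounds with values here, in a physicochemical assay, with a stated time of 6 min (a higher number here means a weaker inhibitor, a lower number a stronger inhibitor), compound 1 (`O=C(Nc1ccc(I)cc1)Nc1nc(-c2cc3ccccc3o2)cs1`) gives 62000 nM as the only numeric reading so far. Compound 2 (`Cc1ccc(NC(=O)Nc2nc(-c3cc4cc(Br)ccc4o3)cs2)cc1`) reads > 200000 nM in this assay and that is a limit of the assay, not a number. Its position is therefore open-ended (the limit of > 200000 nM in this assay, at which 1 of the 2 values shown sits). Compound 3 (`O=C(Nc1ccc(F)cc1)Nc1nc(-c2cc3cc(Br)ccc3o2)cs1`) has fluoro in place of methyl on an aromatic carbon, para to a large group (fluoro in place of methyl on an aromatic carbon). Within the data shown here, no measured step isolates a single change, so this one cannot be sized directly. Among the measured compounds shown here, a small move toward stronger inhibition in this assay is expected, resting only on compound 1 at 62000 nM as the one reading that falls on a number. The expected change is an at least 1.8-fold lower number from compound 2 to compound 3 (0.25 log units; that floor lies within the scatter) and a reading at the limit remains possible. For compound 3 the estimate is 110000 nM with an expected range from 40000 nM to 200000 nM in this assay for now.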

Compound 3, half-maximal inhibitory concentration: > 200000 nM
Compound 3 gave a limit, no number; the forecaster's own chance of this, stated with the estimate: 45%; middle value at least 1.8-fold (0.25 log units) from the limit.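

Compound 2 and compound 3 both read as limits in this assay, not numbers, so no step can be read for fluoro in place of methyl: the limit of > 200000 nM in this assay, at which 2 of the 3 values shown sit.

Left open is whether 4-methylphenyl and 4-fluorophenyl differ at all in this assay on the shared core.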